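A Ring Swapped for a Chain in Compound 1

The source may report more compounds than this note shows. Statements on the series, on what has been measured and on what is new or still open speak of the compounds shown alone.

Compound 1 `CCC[C@H](C)Nc1ncc2c(-c3ccc(CN4CCCN(C)CC4)cc3)cn([C@H]3CC[C@H](O)CC3)c2n1`: 3.3 L/kg
Compound 2 `CCC[C@H](C)Nc1ncc2c(-c3ccc(S(=O)(=O)N4CCN(C)CC4)cc3F)cn([C@H]3CC[C@H](O)CC3)c2n1`: 0.98 L/kg

Both numbers come from an ADME assay on the whole organism for pharmacokinetics, with Mus musculus as the target, at a dose of 3 mg/kg by the intravenous route; a higher number here means that more of the compound sits outside the plasma, a lower number that more of the compound stays in the plasma. Compound 1 holds the higher of the two at 3.3 L/kg, and compound 2 gives 0.98 L/kg, a gap beyond the usual scatter. Compound 3 `CCC[C@H](C)Nc1ncc2c(-c3ccc(CNCCN(CC)CC)cc3)cn([C@H]3CC[C@H](O)CC3)c2n1` has not yet been measured. It departs from compound 1 in one place: (2-(diethylamino)ethyl)amino in place of 4-methyl-1,4-diazepan-1-yl on a saturated chain carbon bound to an aromatic carbon. Within the data shown here, no pair of measured compounds differs in just one place, so no measured step speaks to this change. In this assay no step beyond the scatter is expected, and no direction can be favoured. The expected step is a 1.1-fold higher number from compound 1 to compound 3 (0.04 log units; within the scatter). This expectation rests on compound 1 at 3.3 L/kg. The estimate for compound 3 is 3.6 L/kg, within an expected range of 1.8 L/kg to 7.5 L/kg.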

Compound 3, volume of distribution at steady state: 16.4 L/kg
The estimate for compound 3 lay 4.6-fold (0.66 log units) below the measured number; the whole stated range lies below it.
By their numbers in this assay, from the lowest: compound 2; then compound 1; then compound 3.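

In this assay, replacing the 4-methyl-1,4-diazepan-1-yl ring with the open (2-(diethylamino)ethyl)amino chain on a saturated chain carbon bound to an aromatic carbon gave a 5.0-fold higher number from compound 1 to compound 3 (0.70 log units; beyond the scatter). This position is therefore not indifferent to the change, even though the leaving and entering groups have the same heavy-atom count. They differ in that the entering group has no ring and carries a hydrogen-bond donor, and nothing available explains the step. The compounds shown leave open whether losing the ring or gaining the donor matters more, a question that a methyl group on the linking nitrogen of the chain could help separate. Also open, as far as these compounds go, is how a shorter chain, such as (2-(dimethylamino)ethyl)amino, or a piperazine ring would read at this position.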